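Taking the methoxy off compound 3

This account rests on a few compounds, and the source may have more. Where it says the series, first, only, none or still open, it means among the compounds named here.

Compound 3 (`COc1ccc2nc(Cl)c(/C=C\c3cc(C(F)(F)F)cc(C(F)(F)F)c3)cc2c1`) reads 7970 nM in an ADME assay on 184B5 cells (Homo sapiens) for antiproliferative activity, read by sulforhodamine B assay, with a stated time of 72 h (a higher number here means a weaker inhibitor, a lower number a stronger inhibitor), and cannot be set apart from the other two measured compounds: compound 1 (`FC(F)(F)c1cccc(/C=C\c2cc3ccccc3nc2Cl)c1`) reads 6150 nM and compound 2 (`COc1ccc2nc(Cl)c(/C=C\c3cccc(C(F)(F)F)c3)cc2c1`) reads 5580 nM and all three lie within the usual scatter of one another. Compound 4 (`FC(F)(F)c1cc(/C=C\c2cc3ccccc3nc2Cl)cc(C(F)(F)F)c1`) is still unmeasured. Compared with compound 3, it carries hydrogen in place of methoxy on an aromatic carbon. The closest measured change is the same swap run the other way on a core with one trifluoromethyl, which gave a 1.1-fold lower number from compound 1 to compound 2 (0.04 log units; within the scatter) and so barely moved the number. Adding a second trifluoromethyl gave a 1.4-fold higher number from compound 2 to compound 3 (0.15 log units; within the scatter) and that step also stayed small. Neither step points to a real shift, so no change beyond the scatter is expected in this assay here. The estimated step is a 1.0-fold higher number from compound 3 to compound 4 (0.01 log units; within the scatter) and its direction is not expected to be meaningful. For compound 4 an estimate of 8200 nM is expected, with a range of 4800 nM to 13500 nM around it.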

Compound 4, half-maximal inhibitory concentration: 13700 nM
Estimate against measurement, compound 4: 1.7-fold (0.22 log units) below; measured number above the stated range.
By their numbers in this assay, from the lowest: compounds 2, 1, 3 and 4 (each within the scatter of the next, the first and the last beyond it).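

In this assay, taking the methoxy off gives a 1.7-fold higher number from compound 3 to compound 4 (0.24 log units; within the scatter), so this swap stays within the scatter on the core with two trifluoromethyl groups, as it did on the core with one, and the two steps agree: the same change on two cores in this assay, a 1.1-fold lower number (0.04 log units; within the scatter) from compound 1 to compound 2 and a 1.7-fold lower number (0.24 log units; within the scatter) from compound 4 to compound 3, 1.6-fold (0.19 log units) apart, within the scatter of two such steps. Adding the second trifluoromethyl to the core without methoxy gives a 2.2-fold higher number from compound 1 to compound 4 (0.35 log units; beyond the scatter), the first step in this series to pass beyond the scatter, though only modestly. The same change stayed within the scatter on the methoxy core, but the two steps cannot be told apart, so no dependence on the core can be claimed: the same change on two cores in this assay, a 1.4-fold higher number (0.15 log units; within the scatter) from compound 2 to compound 3 and a 2.2-fold higher number (0.35 log units; beyond the scatter) from compound 1 to compound 4, 1.6-fold (0.19 log units) apart, within the scatter of two such steps.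

The compounds shown leave open whether a different group at the methoxy position, such as an amine or a carboxylic acid, would move the number beyond the scatter. They also leave open whether a longer chain there, such as an ethoxy, would behave like methoxy.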